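Bis-diazeniumdiolate series: from compound 1 to compound 4

The compounds below may be only part of what the source reports. "The series", "measured", "known", "first", "only" and "open" are said of these compounds alone.

Values in a functional assay on HL-60 cells (Homo sapiens) for antiproliferative activity, read by MTT assay, with a stated time of 72 h (on this read-out higher numbers stand for weaker inhibition of growth and lower numbers for stronger inhibition of growth), for the measured compounds:
- compound 1 `CCOC(=O)N1CCN(/[N+]([O-])=N/Oc2cc(O/N=[N+](\[O-])N(C)C)c([N+](=O)[O-])cc2[N+](=O)[O-])CC1` gives 2000 nM
- compound 2 `CCCCOC(=O)N1CCN(/[N+]([O-])=N/Oc2cc(O/N=[N+](\[O-])N(C)C)c([N+](=O)[O-])cc2[N+](=O)[O-])CC1` gives 2700 nM
- compound 3 `CCN(CC)C(=O)N1CCN(/[N+]([O-])=N/Oc2cc(O/N=[N+](\[O-])N(C)C)c([N+](=O)[O-])cc2[N+](=O)[O-])CC1` gives 4900 nM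

Compound 1 stands at the low end of these numbers, level within the scatter with compound 2. Going by the values given here, compound 3 is the only one separated from compound 1 beyond the scatter.

Compound 4 `CN(C)/[N+]([O-])=N/Oc1cc(O/N=[N+](\[O-])N2CCCC2CO)c([N+](=O)[O-])cc1[N+](=O)[O-]` carries 2-(hydroxymethyl)pyrrolidin-1-yl in place of 4-(ethoxycarbonyl)piperazin-1-yl on a double-bonded nitrogen. Among the compounds with values here, three measured steps bear on this only indirectly. The largest, a 2.5-fold higher number from compound 1 to compound 3 (0.39 log units; beyond the scatter), is modest, while a 1.4-fold higher number from compound 1 to compound 2 (0.13 log units; within the scatter) and a 1.8-fold higher number from compound 2 to compound 3 (0.26 log units; within the scatter) lie within the scatter. All three alter only what sits on the carbonyl, and none replaces the whole ring, so the data hold no direct measure of this change. No direction can be read from them either.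

Within the data shown here, the series so far spans little, so no step beyond the scatter is expected in this assay, though the uncertainty is wide in both directions. The expected step is a 1.3-fold higher number from compound 1 to compound 4 (0.10 log units; within the scatter) and carries that uncertainty. For compound 4 the estimated value is 2500 nM and the expected range runs from 800 nM to 8000 nM in this estimate.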

Compound 4, concentration for total growth inhibition: 2000 nM
Estimate against measurement, compound 4: 1.3-fold (0.10 log units) above; low and high end bracket the measured number.
By their numbers in this assay, from the lowest: compounds 1, 4, 2 and 3 (each within the scatter of the next, the first and the last beyond it).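

Notes on the exchange of the whole ring: in this assay, 2-(hydroxymethyl)pyrrolidin-1-yl in place of 4-(ethoxycarbonyl)piperazin-1-yl on a double-bonded nitrogen gives no change at the digits printed from compound 1 to compound 4 (within the scatter), so this position accepts a change far larger than the earlier steps, which altered only what sits on the carbonyl. Here the carbonyl itself leaves, along with the six-membered ring, while a five-membered ring and a hydrogen-bond donor enter, and for this pair the level of growth inhibition does not depend on the ethoxycarbonyl group. No measurement at hand accounts for the two groups reading alike.

Open, going by these compounds, is whether the hydroxymethyl group matters at all: an unsubstituted pyrrolidin-1-yl, or a pyrrolidin-1-yl bearing an aminomethyl group or a carboxylic acid in its place, would test this on the same double-bonded nitrogen. Equally open, on these data alone, is how a free piperazin-1-yl with its secondary amine would read, and what replacing the dimethylamino group, constant across all four compounds, would do.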